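Swapping a dichlorophenyl for an acyl hydrazide

A few compounds are considered here, and "the series" means these few. Any claim that something is new, unique, unknown or untested is made for them only; others in the source may bear on it.

Of the compounds shown here, two sharing one core have been measured in a physicochemical assay for lipophilicity, read by HPLC, in phosphate buffer, measured as chromatographic lipophilicity, at pH 7.4; on this read-out higher numbers stand for higher lipophilicity and lower numbers for lower lipophilicity. Compound 1 `COc1ccc2nc(C)c(NC(=O)C(=O)Nc3cc(C)cc(C)c3)c(O)c2c1` gives 3.76 in this assay. Compound 2 `COc1ccc2nc(C)cc(OCC(=O)Nc3ccc(Cl)cc3Cl)c2c1` gives 6.4 in this assay, the higher of the two numbers, and its gap to compound 1 lies beyond the scatter. Compound 3 `COc1ccc2nc(C)cc(OCC(=O)NNC(=O)c3ccncc3)c2c1` has not yet been measured. It differs from compound 2 in a single place: ((pyridin-4-yl)carbonyl)amino in place of 2,4-dichlorophenyl on an amide-type nitrogen The group that leaves carries no hydrogen-bond donors or acceptors, while the group that enters brings one hydrogen-bond donor, two hydrogen-bond acceptors and a six-membered aromatic ring with one hetero atom. Going by the values given here, no measured pair shows a step of this kind, so the size of the change must be judged from the structures alone. A large fall in this assay is expected, starting from the position of compound 2 at 6.4. The expected step is a number 3.60 log units lower from compound 2 to compound 3 (beyond the scatter), a drop well beyond the scatter. Compound 3 is estimated at 2.8, with a range from 1.8 to 3.8.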

Compound 3, distribution coefficient: 1.48
Compound 3: middle estimate off by 1.32 log units, on the high side; measured number below the stated range.
By their numbers in this assay, from the lowest: compound 3; then compound 1; then compound 2.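

In this assay, putting ((pyridin-4-yl)carbonyl)amino in place of 2,4-dichlorophenyl on an amide-type nitrogen gives a number 4.92 log units lower from compound 2 to compound 3 (beyond the scatter). Going by these compounds alone, the earlier compounds offered no pair differing in one place, so this step is the first sign that a change at this position alone can shift the read-out by a large amount. The exchange alters several things at once, removing both chlorines, adding a ring nitrogen and bringing in a carbonyl and a hydrogen-bond donor, and nothing available here shows which of these accounts for the size of the step.

As far as these compounds go, what stays open is how this large step divides among those features, and whether it would be of similar size on a different core. A plain phenyl, a pyridin-4-yl attached directly to the amide-type nitrogen or a benzoylamino group at the same place would each change fewer features at once, and so could begin to separate the contribution of the ring nitrogen from that of the added carbonyl and amino link.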